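Swapping bromo for hydroxy on two hydrazone cores

The source may report more compounds than this note shows. Statements on the series, on what has been measured and on what is new or still open speak of the compounds shown alone.

Of the compounds shown here, three of one series have been measured in a physicochemical assay for lipophilicity, measured as octanol-water partition; a higher number here means a more lipophilic compound, a lower number a more polar compound. Compound 1, with the structure `O=C(COc1cccc2ccccc12)N/N=C/c1ccccc1Br`, gives 4.81. Compound 2, with the structure `O=C(COc1cccc2ccccc12)N/N=C/c1ccccc1O`, carries a hydroxy where compound 1 carries a bromo, the change being (hydroxy in place of bromo on an aromatic carbon), and in this assay compound 2 gives 3.73. That single swap made the step of a number 1.08 log units lower from compound 1 to compound 2 (beyond the scatter).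

Compound 3, with the structure `C/C(=N\NC(=O)COc1cccc2ccccc12)c1ccc(Br)cc1`, belongs to a second core; the difference between the two cores is not broken down here. In this assay compound 3 gives 3.61, a number that sits within the scatter of the value of compound 2.

Compound 4, with the structure `C/C(=N\NC(=O)COc1cccc2ccccc12)c1ccc(O)cc1`, is not yet measured. It differs from compound 3 by hydroxy in place of bromo on an aromatic carbon. This is the same kind of change as that from compound 1 to compound 2, though not the same: in compound 2 the hydroxy sits ortho to a large group, whereas in compound 4 it sits para to a large group. Among the compounds with values here, the expectation is that the step will be of similar size, that is a number 1.06 log units lower from compound 3 to compound 4 (beyond the scatter), because a number 1.08 log units lower from compound 1 to compound 2 (beyond the scatter) was the only step of this kind seen so far, and a single pair cannot show how much the place matters. Compound 4 is therefore expected to give about 2.55 in this assay, estimated to lie between 2.1 and 3.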

Compound 4, partition coefficient: 4.44
Compound 4: middle estimate off by 1.89 log units, on the low side; the whole stated range lies below it.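

In this assay the same swap of hydroxy for bromo gave a number 1.08 log units lower from compound 1 to compound 2 (beyond the scatter), yet here it gives a number 0.83 log units higher from compound 3 to compound 4 (beyond the scatter), so both steps lie beyond the scatter and point in opposite directions. This shows that, in this series, the size and even the direction of the step seen on one core could not be carried over to the other, and that a single pair is a poor guide to a second one. It does not show which difference matters, since the two pairs differ both in their core and in where the swap sits on the aromatic ring, and nothing measured here accounts for the reversal.

The compounds shown leave open whether the core or the place decides the direction of the step, a question that a bromo and hydroxy pair on the core of compound 1, with the swap para to a large group, would help to settle. They also leave open whether other groups in place of the bromo, such as an amine or a carboxylic acid, would follow the step of the first pair, that of the second, or neither.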